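Swapping the Aryl Group on Silicon: Trifluoromethyl to Formyl

The source may report more compounds than this note shows. Statements on the series, on what has been measured and on what is new or still open speak of the compounds shown alone.

Compound 1 `CCN(C/C=C/C#CC(C)(C)C)Cc1cccc(OC[Si](C)(C)c2ccc(C)cc2)c1` gives 120 nM in a functional assay on liver (Sus scrofa) for inhibition of squalene monooxygenase (Homo sapiens), using microsomes; on this read-out lower numbers stand for stronger inhibition and higher numbers for weaker inhibition.
Compound 2 `CCN(C/C=C/C#CC(C)(C)C)Cc1cccc(OC[Si](C)(C)c2ccc(OC)cc2)c1` gives 870 nM.
Compound 3 `CCN(C/C=C/C#CC(C)(C)C)Cc1cccc(OC[Si](C)(C)c2ccccc2C(F)(F)F)c1` gives 70 nM.

Compound 3 shows the lowest number of the three, but one of its two gaps is a 1.7-fold lower number from compound 1 to compound 3 (0.23 log units; within the scatter), so these two cannot be told apart, whereas the other gap is a 12-fold lower number from compound 2 to compound 3 (1.09 log units; beyond the scatter). Compound 4 `CCN(C/C=C/C#CC(C)(C)C)Cc1cccc(OC[Si](C)(C)c2ccc(C=O)cc2)c1` is reached from compound 3 by one change: 4-formylphenyl in place of 2-(trifluoromethyl)phenyl on a silicon.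

For the measured compounds named here, two measured steps bear on this. The change from methyl to methoxy on the aromatic carbon gave a 7.3-fold higher number from compound 1 to compound 2 (0.86 log units; beyond the scatter), the only case here where a group with a hydrogen-bond acceptor enters the aryl ring, and the reverse of a 12-fold lower number from compound 2 to compound 3 (1.09 log units; beyond the scatter) removes it again. The entering 4-formylphenyl also carries one hydrogen-bond acceptor, so a higher number, beyond the scatter, is expected. Compound 4 is therefore estimated at 500 nM in this assay, between 150 nM and 2000 nM. That estimate corresponds to a 7.1-fold higher number from compound 3 to compound 4 (0.85 log units; beyond the scatter).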

Compound 4, half-maximal inhibitory concentration: 100 nM
Beside the measured number, compound 4's estimate is 5.0-fold (0.70 log units) above it; measured number below the stated range.
By their numbers in this assay, from the lowest: compounds 3, 4 and 1 (each within the scatter of the next); then compound 2.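

In this assay, a hydrogen-bond acceptor on the aryl ring does not by itself decide the number: 4-formylphenyl and 4-methoxyphenyl each carry one, yet formyl in place of methoxy gives an 8.7-fold lower number from compound 2 to compound 4 (0.94 log units; beyond the scatter). The silicon position also accepts quite different aryl groups, since 4-formylphenyl in place of 2-(trifluoromethyl)phenyl gives a 1.4-fold higher number from compound 3 to compound 4 (0.15 log units; within the scatter), and formyl in place of methyl gives a 1.2-fold lower number from compound 1 to compound 4 (0.08 log units; within the scatter), leaving compound 2 as the only one of the four set apart. No measurement shown here explains why the methoxy compound differs from the other three.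

The compounds shown leave open how a hydroxyl, an amine or a carboxylic acid on this aryl ring would read. They also leave open whether a longer ether, such as ethoxy, would follow methoxy or formyl.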